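Swapping a pyridine for a phenyl on the acyl group

The source may report more compounds than this note shows. Statements on the series, on what has been measured and on what is new or still open speak of the compounds shown alone.

Measured compounds: compound 1 `O=C(c1ccncc1)n1c(-c2cn(-c3ccccc3)nc2-c2ccc(C(F)(F)F)cc2)nc2ccccc21` with 135000 nM, and compound 2 `Cc1ccc(C(=O)n2c(-c3cn(-c4ccccc4)nc3-c3ccc(C(F)(F)F)cc3)nc3ccccc32)cn1` with 153000 nM, both in an ADME assay on HEK-293T cells (Homo sapiens) for cytotoxicity, read by MTT assay, with a stated time of 24 h; on this read-out lower numbers stand for higher toxicity in this test and higher numbers for lower toxicity in this test.

Within the data shown here, compound 2 stands at the highest of the two numbers, and its only neighbour, compound 1, lies within the scatter of it. Compound 3 `Cc1ccccc1C(=O)n1c(-c2cn(-c3ccccc3)nc2-c2ccc(C(F)(F)F)cc2)nc2ccccc21` differs from compound 2 in one place: 2-methylphenyl in place of 6-methylpyridin-3-yl on a carbonyl carbon. Among the measured compounds shown here, no measured step tests this particular change. For the measured compounds named here, the only step at hand, a 1.1-fold higher number from compound 1 to compound 2 (0.05 log units; within the scatter), stayed within the scatter, so no step beyond the scatter is expected. Compound 3 is therefore estimated at 140000 nM, between 60000 nM and 320000 nM, a step of a 1.1-fold lower number from compound 2 to compound 3 (0.04 log units; within the scatter).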

Compound 3, half-maximal cytotoxic concentration: 179000 nM
Compound 3: the middle estimate sits 1.3-fold (0.11 log units) below what was measured; low and high end bracket the measured number.
By their numbers in this assay, from the lowest: compounds 1, 2 and 3 (each within the scatter of the next).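

In this assay, 2-methylphenyl on the carbonyl carbon gives a 1.2-fold higher number from compound 2 to compound 3 (0.07 log units; within the scatter), and a 1.3-fold higher number from compound 1 to compound 3 (0.12 log units; within the scatter). The earlier pair compared only pyridine rings, whereas these steps show that a ring of carbon only, without the ring nitrogen, also stays within the scatter at this position. No measurement at hand explains why these compounds read alike. The compounds shown leave open whether any group here can move the number beyond the scatter. An amine or a carboxylic acid on the ring, or a longer chain replacing it, would test that.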